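Adding a Third Methoxy: Expected Growth Inhibition

The source may hold more compounds than are shown below. What is called first, only, known or untested is meant among the compounds shown, and "the series" means these compounds.

Compound 1 `COc1ccc(/C=C/C2CC=CC(=O)O2)cc1`: 33.7 uM
Compound 2 `COc1ccc(/C=C/C2CC=CC(=O)O2)cc1OC`: 17.2 uM

Both were tested in a functional assay on HT-29 cells (Homo sapiens) for inhibition, read by sulforhodamine B assay, with a stated time of 48 h; on this read-out lower numbers stand for stronger inhibition of growth and higher numbers for weaker inhibition of growth. Among the compounds with values here, compound 2 has the lower of the two numbers; its only neighbour is compound 1, and the gap between them, a 2.0-fold lower number from compound 1 to compound 2 (0.29 log units; within the scatter), lies within the scatter, so no real order between the two can be claimed. Compound 3 `COc1cc(/C=C/C2CC=CC(=O)O2)cc(OC)c1OC` has not yet been measured. It differs from compound 2 by methoxy in place of hydrogen on an aromatic carbon. Within the data shown here, the one measured step that bears on this change is a 2.0-fold lower number from compound 1 to compound 2 (0.29 log units; within the scatter), itself a methoxy in place of hydrogen on an aromatic carbon, and it stayed within the scatter. A step of similar small size is therefore expected in this assay, leaning toward a lower number but possibly none beyond the scatter. For compound 3 the expected step is a 1.4-fold lower number from compound 2 to compound 3 (0.16 log units; within the scatter). The estimate for compound 3 is 12 uM, within a range from 4 uM to 36 uM.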

Compound 3, concentration for growth inhibition (reported as GI): 18.8 uM
Beside the measured number, compound 3's estimate is 1.6-fold (0.19 log units) below it; low and high end bracket the measured number.
By their numbers in this assay, from the lowest: compounds 2, 3 and 1 (each within the scatter of the next).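

In this assay, methoxy in place of hydrogen on the aromatic carbon that is ortho to a methoxy group and meta to another gives a 1.1-fold higher number from compound 2 to compound 3 (0.04 log units; within the scatter) and so shows no difference that can be claimed. The earlier change of the same kind, a 2.0-fold lower number from compound 1 to compound 2 (0.29 log units; within the scatter), also stayed within the scatter, so this change has now twice left the growth-inhibition number without a real shift, here at a new place on the ring. Nothing available explains this result.

Going by these compounds, whether a different group at this position, such as a hydroxyl, an amine or a longer alkoxy chain, would move the number beyond the scatter remains open. Also open, on these data alone, is whether changes to the rest of the shared core would matter more than these methoxy changes.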